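Swapping the aryl group on the acrylic acid chain

The compounds below may be only part of what the source reports. "The series", "measured", "known", "first", "only" and "open" are said of these compounds alone.

Compound 1 `CC(=O)n1cc(/C=C(/C(=O)O)c2ccc(Cl)cc2)c2cc(OCc3ccccc3)ccc21` belongs to a small set of acrylic acids tested in a functional assay on M14 cells (Homo sapiens) for cytotoxicity, read by MTT assay, with a stated time of 72 h; on this read-out higher numbers stand for weaker inhibition and lower numbers for stronger inhibition. In this assay compound 1 reaches only a limit of the assay, > 100000 nM, and so it stands at the limit of > 100000 nM in this assay, at which 1 of the 3 values shown sits, rather than at a measured number. Within the data shown here, compound 2 `O=C(O)/C(=C/c1c[nH]c2ccc(OCc3ccccc3)cc12)c1ccccc1` gives 95200 nM in this assay, and compound 3 `COc1ccc(Cn2cc(/C=C(/C(=O)O)c3ccccc3)c3cc(OCc4ccccc4)ccc32)cc1` gives 64500 nM; the single measured step, a 1.5-fold lower number from compound 2 to compound 3 (0.17 log units; within the scatter), stays within the scatter. Compound 4 `COc1ccccc1/C(=C\c1cn(C(C)=O)c2ccc(OCc3ccccc3)cc12)C(=O)O` differs from compound 1 by 2-methoxyphenyl in place of 4-chlorophenyl on a double-bonded chain carbon bound to a carbonyl carbon and a double-bonded chain carbon. Among the measured compounds shown here, no measured step touches this change, so the data give no direction for it. Compound 4 is expected to remain weak, with a number no higher from compound 1 to compound 4 (the limit leaves the size open), and its estimated value is 100000 nM, in a range from 35000 nM to 300000 nM.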

Compound 4, half-maximal inhibitory concentration: > 100000 nM
Compound 4: only a limit was reported; the forecaster's own chance of this, stated with the estimate: 55%; the middle value lies on the limit itself.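

Compound 1 and compound 4 both stop at a limit in this assay, so the step between them cannot be read: the limit of > 100000 nM in this assay, at which 2 of the 4 values shown sit. The compounds shown leave open whether 2-methoxyphenyl and 4-chlorophenyl differ at all in this place.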